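Extending the propyl chain of compound 2 to pentyl

The compounds below may be only part of what the source reports. "The series", "measured", "known", "first", "only" and "open" are said of these compounds alone.

Within the data shown here, in a functional assay on brain (Rattus norvegicus, strain Wistar) for inhibition (a higher number here means a weaker inhibitor, a lower number a stronger inhibitor), only two compounds have values so far: compound 1 `CCCCc1ccc(-c2c(CC)[nH]c(=O)n2C)cc1` gives 13900 nM and compound 2 `CCCc1ccc(-c2c(C)[nH]c(=O)n2C)cc1` gives 21500 nM. These two values lie within the scatter of each other, so compound 2 cannot be separated from compound 1 on the numbers shown. Compound 3 `CCCCCc1ccc(-c2c(C)[nH]c(=O)n2C)cc1` differs from compound 2 by ethyl in place of hydrogen on a saturated chain carbon, three bonds along the chain from an aromatic carbon, which also reads as propyl to pentyl. Among the measured compounds shown here, no measured pair isolates this change, so the expectation is tentative: a modest move towards a lower number in this assay, only slightly beyond the scatter. The expected change is a 2.2-fold lower number from compound 2 to compound 3 (0.33 log units; beyond the scatter). The estimate for compound 3 is 10000 nM, with an expected range of 3500 nM to 28000 nM.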

Compound 3, half-maximal inhibitory concentration: 5900 nM
Compound 3: middle estimate off by 1.7-fold (0.23 log units), on the high side; the range from low to high includes it.
By their numbers in this assay, from the lowest: compound 3; then compounds 1 and 2 (each within the scatter of the next).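

In this assay, among these compounds, the change from propyl to pentyl brings a 3.6-fold lower number from compound 2 to compound 3 (0.56 log units; beyond the scatter) on the shared core, the first comparison that differs in one place only. Compound 1 and compound 2 differ in more than one place and could not isolate this change, so the chain length at this position now has a reading of its own, though from this single pair alone. No measurement shown here bears on why the number falls.

On these data alone, a single step gives no trend: what a butyl or hexyl chain would give on this core stays open, as does whether the number would keep falling with a longer chain. Also open, as far as these compounds go, is how an amine or a carboxylic acid at the end of this chain would compare with pentyl.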